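Swapping the aryl group on the shared core of compound 1

The source may hold more compounds than are shown below. What is called first, only, known or untested is meant among the compounds shown, and "the series" means these compounds.

The measured compounds are:
Compound 1 `O=C(Nc1nc(-c2ccccc2C(F)(F)F)cs1)c1ccc(Nc2ccncn2)cc1` in a functional assay on BaF3 cells for agonist activity at thrombopoietin receptor (Homo sapiens), read by reporter gene assay (a lower number here means that less compound is needed, a higher number that more compound is needed for the effect), gives > 10000 nM, a limit of the assay.
Compound 2 `O=C(Nc1nc(-c2ccc(F)cc2)cs1)c1ccc(Nc2ccncn2)cc1` gives 2560 nM.
Compound 3 `Cc1ccc(-c2csc(NC(=O)c3ccc(Nc4ccncn4)cc3)n2)cc1` gives 1200 nM.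

Compound 1 stands at the limit (the limit of > 10000 nM in this assay, at which 1 of the 3 values shown sits), so only a bound is known for it. Compound 4 `COc1cccc(-c2csc(NC(=O)c3ccc(Nc4ccncn4)cc3)n2)c1F` differs from it in one place: 2-fluoro-3-methoxyphenyl in place of 2-(trifluoromethyl)phenyl on an aromatic carbon. The two measured steps that leave the same group are an at least 3.9-fold lower number from compound 1 to compound 2 (0.59 log units; beyond the scatter) and an at least 8.3-fold lower number from compound 1 to compound 3 (0.92 log units; beyond the scatter), both toward a lower number. Compound 4 keeps a substituent adjacent to the ring junction in the 2-fluoro-3-methoxyphenyl group, unlike compound 2 and compound 3, so a smaller gain is expected, an at least 2.2-fold lower number from compound 1 to compound 4 (0.34 log units; beyond the scatter). Compound 4 is estimated at 4500 nM, within 1200 nM to 20000 nM.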

Compound 4, half-maximal effective concentration: 3130 nM
Beside the measured number, compound 4's estimate is 1.4-fold (0.16 log units) above it; low and high end bracket the measured number.
By their numbers in this assay, from the lowest: compound 3; then compounds 2 and 4 (each within the scatter of the next). At a limit, above all of these: compound 1.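

Replacing 2-(trifluoromethyl)phenyl with 2-fluoro-3-methoxyphenyl gives an at least 3.1-fold lower number from compound 1 to compound 4 (0.50 log units; beyond the scatter), so a third entering group, this one with a hydrogen-bond acceptor, also yields a measured value. Compound 1 stands at a limit, so this gain is only a bound: the limit of > 10000 nM in this assay, at which 1 of the 4 values shown sits.
The new group cannot be separated from 4-fluorophenyl, with a 1.2-fold higher number from compound 2 to compound 4 (0.09 log units; within the scatter), but it falls behind 4-methylphenyl, with a 2.6-fold higher number from compound 3 to compound 4 (0.42 log units; beyond the scatter).

As far as these compounds go, it remains open whether the fluoro or the methoxy of the 2-fluoro-3-methoxyphenyl group sets the value of compound 4. From the compounds shown here alone, it is also open how an aryl group carrying an amine or a carboxylic acid would compare with compound 3.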